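A few compounds are considered here, and "the series" means these few. Any claim that something is new, unique, unknown or untested is made for them only; others in the source may bear on it.

Two amides of the shared core have been measured in a functional assay on the whole organism (strain C57BL/6) for inhibition, with Mus musculus as the target, read by paw edema, with stated times of 1 h and 4 h, at a dose of 100 mg/kg by the oral route; a higher number here means more inhibition at the dose given (going by the name of the read-out), a lower number less inhibition. Compound 1 `COc1cccc(NC(=O)CCc2nc(Cc3ccc(NC(C)=O)cc3)no2)c1` gives 35.6%, and compound 2 `COc1ccc(NC(=O)CCc2nc(Cc3ccc(NC(C)=O)cc3)no2)cc1F` gives 60.3%. Going by the values given here, the one known step, a number 24.7 percentage points higher from compound 1 to compound 2 (beyond the scatter), is the only guide. Among the compounds with values here, compound 2 therefore stands highest of the two numbers so far, with compound 1 the nearest and lower by that step. Compound 3 `COc1ccc(NC(=O)CCc2nc(Cc3ccc(NC(C)=O)cc3)no2)cc1OC` is not yet measured; its change from compound 2 is methoxy in place of fluoro on an aromatic carbon. Within the data shown here, no measured step removes a fluoro or adds a methoxy at that place; the step from compound 1 to compound 2 moved the methoxy and added the fluoro at once, so it bears on the present change only loosely. In this assay no shift beyond the scatter is expected in either direction, and the estimate for compound 3 is 52%, within 28% to 76%, meaning an expected step of a number 8.3 percentage points lower from compound 2 to compound 3 (within the scatter).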

Compound 3, a percentage reported as inhibition, in the whole organism at one dose (the size of the read-out at that dose, not a potency): 95.9%
The estimate for compound 3 lay 43.9 percentage points below the measured number, and the stated range ends below it.
By their numbers in this assay, from the lowest: compound 1; then compound 2; then compound 3.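

In this assay, the place ortho to a methoxy group proves highly responsive to a single change: methoxy in place of fluoro gives a number 35.6 percentage points higher from compound 2 to compound 3 (beyond the scatter) as a clean one-place comparison, which the earlier step could not offer. Methoxy in place of hydrogen on an aromatic carbon gives a number 60.3 percentage points higher from compound 1 to compound 3 (beyond the scatter) and so puts the 3,4-dimethoxyphenyl amide beyond the scatter above both other amides. Nothing available explains the size of these steps.

As far as these compounds go, it remains open whether this place needs methoxy itself or would accept ethoxy, hydroxy or an amine to a similar degree. Also open, from the compounds shown here alone, is whether the order of the three amides holds at other oral doses, as all three numbers come from a single dose.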